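Hydroxy replaces 2-carboxypiperidin-1-yl in compound 4

The compounds below may be only part of what the source reports. "The series", "measured", "known", "first", "only" and "open" are said of these compounds alone.

In an ADME assay on NCM460 cells (Homo sapiens) for cytotoxicity, read by CCK-8 assay, with a stated time of 48 h (a higher number here means a weaker inhibitor, a lower number a stronger inhibitor), compound 1 `COc1ccc(/C=C\c2cc(OC)c(OC)c(OC)c2)cc1OCc1ccc(CNC(C)(C)C(=O)O)cc1` gives > 50000 nM as a limit of the assay. Compound 2 `COc1ccc(/C=C\c2cc(OC)c(OC)c(OC)c2)cc1OCc1ccc(CN2C[C@H](O)C[C@@H]2C(=O)O)cc1` gives > 50000 nM as a limit too. Compound 3 `COc1ccc(/C=C\c2cc(OC)c(OC)c(OC)c2)cc1OCc1ccc(CN2CCCC[C@H]2C(=O)O)cc1` gives > 50000 nM as a limit and not a number. All three show the same picture, namely the limit of > 50000 nM in this assay, at which 3 of the 3 values shown sit, and nothing finer. Compound 4 `COc1ccc(/C=C\c2cc(OC)c(OC)c(OC)c2)cc1OCc1ccc(CO)cc1` differs from compound 3 at one place (hydroxy in place of 2-carboxypiperidin-1-yl on a saturated chain carbon bound to an aromatic carbon), with hydroxy in place of 2-carboxypiperidin-1-yl on a saturated chain carbon bound to an aromatic carbon. The steps a step that the two limits leave unreadable from compound 1 to compound 3 and a step that the two limits leave unreadable from compound 2 to compound 3 only exchange one carboxy-bearing group for another, and neither gives a size to carry over. Within the data shown here, no measured compound lacks a carboxy group, so the expectation is loose. The expected move is toward stronger inhibition in this assay with an at least 6.2-fold lower number from compound 3 to compound 4 (0.79 log units; beyond the scatter) as the estimated size. For compound 4 the estimated value is 8000 nM in an expected range from 400 nM to 50000 nM in this assay.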

Compound 4, half-maximal inhibitory concentration: > 50000 nM
Compound 4 gave a limit, no number (the forecaster's own chance of this, stated with the estimate: 30%); middle value at least 6.2-fold (0.79 log units) from the limit.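

Compound 4 also gives only a limit in this assay, so no step among compound 1, compound 2, compound 3 and compound 4 can be read: the limit of > 50000 nM in this assay, at which 4 of the 4 values shown sit.

The compounds shown leave open whether changing the group on the saturated chain carbon alters the read-out at all.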